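The source may hold more compounds than are shown below. What is called first, only, known or untested is meant among the compounds shown, and "the series" means these compounds.

Measured compounds:
compound 1 `Cc1ccc(NS(=O)(=O)c2ccc3c(c2)CCO3)c(=O)n1CC(=O)NCc1ccc2[nH]nc(N)c2c1` — 3.6
compound 2 `Cc1cnc(NCC2(c3ccccc3)CCC2)c(=O)n1CC(=O)NCc1ccc2[nH]nc(O)c2c1` — 6.3
compound 3 `Cc1cnc(NCC2(c3ccc(F)cc3)CC2)c(=O)n1CC(=O)NCc1ccc2[nH]nc(N)c2c1` — 3.6

In a physicochemical assay for acid dissociation, compound 3 stands level with compound 1 at the digits given, the two together forming the lowest pair of the three numbers; between compound 3 and compound 1 there is no change at the digits shown, which lies within the scatter. Compound 2 is the furthest from compound 3, a number well above it and beyond the scatter. Compound 1 and compound 3 share the 3-amino-1H-indazol-5-yl group, while compound 2 carries a different group on the same saturated chain carbon, and this is where the three numbers part ways.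

Compound 4 `Cc1cnc(NCC2(c3ccc(F)cc3)CC2)c(=O)n1CC(=O)NCc1ccc2c(N)noc2c1` has not yet been measured in this assay. It differs from compound 3 in one place: a group of 10 heavy atoms (7 carbon, 2 nitrogen, 1 oxygen; one five-membered aromatic ring with 2 hetero atoms, one six-membered aromatic ring of carbon only) in place of a group of 10 heavy atoms (7 carbon, 3 nitrogen; one five-membered aromatic ring with 2 hetero atoms, one six-membered aromatic ring of carbon only), on a saturated chain carbon bound to an amide-type nitrogen. For the measured compounds named here, no measured pair shows this change, so its size must be estimated. Since the group at this position is where the measured values diverge, compound 4 is expected to move away from compound 3, and a downward step of a number 1.10 log units lower from compound 3 to compound 4 (beyond the scatter) is estimated, somewhat beyond the scatter. Compound 4 is therefore expected to give about 2.5 in this assay, within a range from 1.4 to 3.7.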

Compound 4, acid dissociation constant: 8.6
For compound 4 the middle estimate is 6.10 log units below the measured one; measured number above the stated range.
By their numbers in this assay, from the lowest: compounds 1 and 3 (each within the scatter of the next); then compound 2; then compound 4.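

In this assay, for the compounds shown here, the one exchange at this place, on a saturated chain carbon bound to an amide-type nitrogen, gives a number 5.00 log units higher from compound 3 to compound 4 (beyond the scatter) and so supplies the first step that can be tied to a single change. Going by these compounds alone, the size of that step shows that this place can move the read-out a long way on its own, and in the upward direction, whereas the earlier compounds differ in more than one place and could not separate it from the rest of the structure. The exchange is a small one by count, with 3-amino-1H-indazol-5-yl and the entering group alike in heavy atoms, in their kinds of ring and in having no net charge, and nothing measured here bears on why so small an exchange gives so large a step.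

The compounds shown leave open whether the proton read in compound 4 is the same one as that read in compound 3. They also leave open how far the number would move with sulfur in the ring of the entering group, or with a carboxylic acid on the same chain carbon.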